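From Diethylamino to Methylamino at the Carbonyl

A few compounds are considered here, and "the series" means these few. Any claim that something is new, unique, unknown or untested is made for them only; others in the source may bear on it.

Compound 1 `CCN(CC)C(=O)[C@@H]1CN[C@H](C(=O)N2CCC[C@H]2C#N)C1`: 43%
Compound 2 `C[C@@H]1N[C@H](C(=O)N2CCC[C@H]2C#N)C[C@@H]1C(=O)N1CCCC1`: 94%

In an assay on the whole organism (plasma, strain Sprague-Dawley) for inhibition of Dipeptidyl peptidase 4 (Rattus norvegicus), with a stated time of 6 h, at a dose of 1 mg/kg by the oral route (a higher number here means more inhibition at the dose given (going by the name of the read-out), a lower number less inhibition), compound 1 gives 43%, the lower of the two numbers measured. Compound 2 gives 94%, a number higher by more than the usual scatter; the two compounds differ in several places at once, so their values show only that gap. Compound 3 `CNC(=O)[C@@H]1CN[C@H](C(=O)N2CCC[C@H]2C#N)C1` differs from compound 1 in one place: methylamino in place of diethylamino on a carbonyl carbon. Among the compounds with values here, no measured pair shows this change, so its direction is unknown. The step of a number 3 percentage points lower from compound 1 to compound 3 (within the scatter) is expected to stay within the scatter. Compound 3 is estimated at 40%, within 15% to 65%.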

Compound 3, a percentage reported as inhibition, in the whole organism at one dose (the size of the read-out at that dose, not a potency): 75%
Beside the measured number, compound 3's estimate is 35 percentage points below it; the whole stated range lies below it.
By their numbers in this assay, from the lowest: compound 1; then compound 3; then compound 2.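

On a carbonyl carbon of the shared core, methylamino in place of diethylamino gives a number 32 percentage points higher from compound 1 to compound 3 (beyond the scatter) in this assay. Within the data shown here, this is the first single change read at this position, and it shows that the group here strongly affects inhibition at the dose given. Nothing measured explains the step.

Still open, from the compounds shown here alone, is how ethylamino or a plain amino group on the same carbonyl carbon would compare with methylamino. Going by these compounds, whether a longer chain, such as propylamino, would keep this gain is also open.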